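Adding a Second Chloro Group to a Thioether Analog

A few compounds are considered here, and "the series" means these few. Any claim that something is new, unique, unknown or untested is made for them only; others in the source may bear on it.

Measured compounds:
Compound 1, `Cc1cc(C)nc(Oc2ccc(NC(=O)Nc3ccc(Cl)cc3)cc2)n1`, gives 20400 nM.
Compound 2, `Cc1cc(C)nc(Oc2ccc(NC(=O)Nc3ccc(Cl)cc3Cl)cc2)n1`, gives 38900 nM.
Compound 3, `Cc1cc(C)nc(Sc2ccc(NC(=O)Nc3ccc(Cl)cc3)cc2)n1`, gives 13500 nM.

All three were tested in a functional assay on CNE-2 cells (Homo sapiens) for cytotoxicity, read by MTT assay, with a stated time of 3 days; on this read-out lower numbers stand for stronger inhibition and higher numbers for weaker inhibition. Compound 1 and compound 2 share one core and differ by a single change, (chloro in place of hydrogen on an aromatic carbon). This change made a step of a 1.9-fold higher number from compound 1 to compound 2 (0.28 log units; within the scatter), so the two numbers cannot be told apart with confidence.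

Compound 3 carries a different core; the difference between the two cores is not broken down here. Its value and that of compound 1 lie within the scatter of each other, while its value and that of compound 2 lie beyond it.

Compound 4, `Cc1cc(C)nc(Sc2ccc(NC(=O)Nc3ccc(Cl)cc3Cl)cc2)n1`, has not yet been measured in this assay. It stands to compound 3 as compound 2 stands to compound 1: the change is chloro in place of hydrogen on an aromatic carbon, and the surroundings of the new chloro group read the same in both pairs, so this is the same change on the other core.

For the measured compounds named here, the only guide is the step seen on the first core. Since that step stayed within the scatter, the step from compound 3 to compound 4 is expected to be of about the same small size, a 1.9-fold higher number from compound 3 to compound 4 (0.27 log units; within the scatter), because compound 1 to compound 2 gave a 1.9-fold higher number from compound 1 to compound 2 (0.28 log units; within the scatter). On that basis compound 4 is estimated at 25000 nM, with a likely range from 10000 nM to 60000 nM. A single pair is a thin basis, so the range is kept wide.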

Compound 4, half-maximal inhibitory concentration: 23200 nM
Compound 4: middle estimate off by 1.1-fold (0.03 log units), on the high side, within the range that was stated.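

In this assay, chloro in place of hydrogen on compound 3, which turns its 4-chlorophenyl into 2,4-dichlorophenyl, gave a 1.7-fold higher number from compound 3 to compound 4 (0.24 log units; within the scatter), so on this core too the two numbers cannot be told apart with confidence. Set beside the step on the core of compound 1, the change looks the same on both cores: the same change on two cores in this assay, a 1.9-fold higher number (0.28 log units; within the scatter) from compound 1 to compound 2 and a 1.7-fold higher number (0.24 log units; within the scatter) from compound 3 to compound 4, 1.1-fold (0.05 log units) apart, within the scatter of two such steps. For the compounds shown here, this agreement does not show that the second chloro group really changes the read-out: both steps lie within the scatter, only two pairs are available, and the two dichloro compounds cannot be separated either, with (4,6-dimethylpyrimidin-2-yl)sulfanyl in place of (4,6-dimethylpyrimidin-2-yl)oxy giving a 1.7-fold lower number from compound 2 to compound 4 (0.22 log units; within the scatter).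

The compounds shown leave open whether a different group on the same aromatic carbon, such as a methoxy group, an amine or a carboxylic acid, would give a step beyond the scatter, and whether such a step would then carry from one core to the other. They also leave open what happens when the methyl groups on the 4,6-dimethylpyrimidin-2-yl part give way to a longer chain.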